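Adding a cyanomethyl group to a weak cytotoxic quinolinone

The source may report more compounds than this note shows. Statements on the series, on what has been measured and on what is new or still open speak of the compounds shown alone.

Three compounds share a bicyclic core carrying methoxy groups and a para-substituted phenyl ring. Compound 1 `COc1ccc(-c2cc3c(OC)ccc(OC)c3nc2O)cc1` gives 10000 nM in a functional assay on MCF7 cells (Homo sapiens) for cytotoxicity, read by colorimetric assay and MTT assay (a higher number here means a weaker inhibitor, a lower number a stronger inhibitor), compound 2 `COc1cc(OC)c2cc(-c3ccc(OCc4ccccc4)cc3)c(O)nc2c1` gives 10000 nM, and compound 3 `COc1ccc(-c2cc3c(OC)cc(OC)cc3n(C)c2=O)cc1` gives 10000 nM. On the numbers shown, compound 3 stands level with compound 1 and with compound 2; none of the three separates from the others beyond the scatter, so all are weak here.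

Compound 4 `COc1ccc(-c2cc3c(OC)cc(OC)cc3n(CCC#N)c2=O)cc1` has not yet been measured. It differs from compound 3 by a single change (cyanomethyl in place of hydrogen on a saturated chain carbon bound to an aromatic nitrogen), a group of three heavy atoms with one triple bond and one hydrogen-bond acceptor, sitting on the saturated chain carbon bound to the aromatic nitrogen. Among the compounds with values here, with no measured step of this kind to draw on, and with every measured compound at the same weak level, no change beyond the scatter is expected from compound 3 to compound 4, and the step is estimated as no change at the digits printed from compound 3 to compound 4 (within the scatter). Compound 4 is therefore expected to give about 10000 nM, within a range of 4000 nM to 25000 nM.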

Compound 4, half-maximal inhibitory concentration: 10000 nM
Estimate against measurement, compound 4: no gap at the digits printed, within the range that was stated.
By their numbers in this assay, from the lowest: compounds 1, 2, 3 and 4 (each within the scatter of the next).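

In this assay, within the data shown here, putting cyanomethyl in place of hydrogen on a saturated chain carbon bound to an aromatic nitrogen gives no change at the digits printed from compound 3 to compound 4 (within the scatter) and so provides the first reading of a change at this position. The same difference can also be read as methyl to 2-cyanoethyl, and this larger group, which carries a triple bond and a hydrogen-bond acceptor, neither strengthens nor weakens the compound measurably here. Nothing measured here offers an explanation for this result.

Going by these compounds, it remains open whether an amine, a carboxylic acid or a longer carbon chain at the same place would separate from compound 3. Also open is whether the cyanomethyl change would matter on a compound that gives a lower number in this assay, since all four compounds shown stand level.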